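Dichlorophenyl to nitrophenyl on the piperazine nitrogen

This account rests on a few compounds, and the source may have more. Where it says the series, first, only, none or still open, it means among the compounds named here.

Measured so far in a functional assay on HepG2 cells (Homo sapiens) for antiproliferative activity, read by MTT assay, with a stated time of 48 h; a higher number here means a weaker inhibitor, a lower number a stronger inhibitor:
- compound 1, `Cc1ccc(N2CCN(Cn3nc(-c4ccc5c(c4)OCCO5)oc3=S)CC2)c(C)c1`: 28400 nM
- compound 2, `S=c1oc(-c2ccc3c(c2)OCCO3)nn1CN1CCN(c2cccc(Cl)c2Cl)CC1`: > 50000 nM, which is a limit of the assay, not a number
- compound 3, `Fc1ccc(N2CCN(Cn3nc(-c4ccc5c(c4)OCCO5)oc3=S)CC2)cc1`: > 50000 nM, also a limit of the assay

Compound 2 stands at the limit (the limit of > 50000 nM in this assay, at which 2 of the 3 values shown sit); its value is not a number, and only compound 1 gives a number in this assay. The steps of an at least 1.7-fold higher number from compound 1 to compound 2 (0.24 log units; that floor lies within the scatter) and an at least 1.7-fold higher number from compound 1 to compound 3 (0.24 log units; that floor lies within the scatter) both have a floor that lies within the scatter, so the three compounds are not separated. The step that the two limits leave unreadable from compound 2 to compound 3 cannot be read, both ends being limits.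

Compound 4, `O=[N+]([O-])c1ccc(N2CCN(Cn3nc(-c4ccc5c(c4)OCCO5)oc3=S)CC2)cc1`, is the next compound of the series. Its change from compound 2: 4-nitrophenyl in place of 2,3-dichlorophenyl on an amine nitrogen in a ring. The changes to compound 2 and compound 3 each replaced the aryl group on the same ring nitrogen and each left the value at the limit, so the closest guide is the step from compound 1, which gives no readable size. The expectation is therefore no step beyond the scatter in this assay, with compound 4 most likely staying at the limit. Compound 4 is expected to give 50000 nM, in the range 20000 nM to 120000 nM. This expectation corresponds to a step of a number no higher from compound 2 to compound 4 (the limit leaves the size open).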

Compound 4, half-maximal inhibitory concentration: 29500 nM
The estimate for compound 4 lay 1.7-fold (0.23 log units) above the measured number; measured number inside the range.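

In this assay, compound 4 gives the series a second number rather than a limit, and the step is a 1.0-fold higher number from compound 1 to compound 4 (0.02 log units; within the scatter), so 4-nitrophenyl and 2,4-dimethylphenyl on the ring nitrogen are not separated. The steps of an at least 1.6-fold lower number from compound 2 to compound 4 (0.22 log units; that floor lies within the scatter) and an at least 1.6-fold lower number from compound 3 to compound 4 (0.22 log units; that floor lies within the scatter) have floors that stay within the scatter, so neither 4-nitrophenyl in place of 2,3-dichlorophenyl nor nitro in place of fluoro is shown to shift the value, even though compound 4 reads as a number. Compound 2 and compound 3 remain limits of the assay and not numbers, and the step that joins those two cannot be read: the limit of > 50000 nM in this assay, at which 2 of the 4 values shown sit.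

Still open, from the compounds shown here alone, is whether any group on this ring nitrogen can give a step beyond the scatter, for instance a benzyl group in place of the aryl group, or a phenyl ring carrying a carboxylic acid or an amine. The compounds shown also leave open how the 4-nitrophenyl reads once the shared core is changed, as all of them keep that core.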